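Chloro on the Benzyl Arm of Compound 2

The compounds below may be only part of what the source reports. "The series", "measured", "known", "first", "only" and "open" are said of these compounds alone.

Compound 2 `Cn1c(-c2ccc(NC(=O)CN3CCN(Cc4ccccc4)CC3)cc2)nc(-c2ccccc2)c1-c1ccccc1` was tested in a functional assay on HT-29 cells (Homo sapiens) for cytotoxicity, read by MTT assay, with a stated time of 24 h, tested at 80 ug/mL (a lower number here means a weaker effect, a higher number a stronger effect of the compound at the concentration tested), where compound 2 gives 54.5%. Among the compounds with values here, its only measured companion is compound 1 `CCN1CCN(CC(=O)Nc2ccc(-c3nc(-c4ccccc4)c(-c4ccccc4)n3C)cc2)CC1`, which in this assay gives 51.2%. Within the data shown here, of the two numbers, the one for compound 2 and the one for compound 1 lie within the usual scatter of each other, so neither can be called the stronger; the single measured step, a number 3.3 percentage points higher from compound 1 to compound 2 (within the scatter), is itself within the scatter.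

Compound 3 `Cn1c(-c2ccc(NC(=O)CN3CCN(Cc4ccc(Cl)cc4)CC3)cc2)nc(-c2ccccc2)c1-c1ccccc1` differs from compound 2 in one place: chloro in place of hydrogen on an aromatic carbon. Among the measured compounds shown here, no measured step shows a chloro entering on an aromatic carbon. For the measured compounds named here, the one step that is known touches the same benzyl region, since it set phenyl in place of methyl on a saturated chain carbon bound to an amine nitrogen in a ring, and it left this assay unchanged within the scatter. Compound 3 is therefore expected to give 55% in this assay, within the range 42% to 68%, and the expected step of a number 0.5 percentage points higher from compound 2 to compound 3 (within the scatter) is estimated to lie within the scatter.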

Compound 3, a percentage reported as activity, at one concentration (the size of the read-out at that concentration, not a potency): 60.7%
Beside the measured number, compound 3's estimate is 5.7 percentage points below it; the measured number falls inside the stated range.
By their numbers in this assay, from the lowest: compounds 1, 2 and 3 (each within the scatter of the next).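

Within the data shown here, this is the first measured change on the aromatic ring of the benzyl arm: with chloro in place of hydrogen on an aromatic carbon, para to a large group, this assay records a number 6.2 percentage points higher from compound 2 to compound 3 (within the scatter) and so gives no reading that can be told apart from that of the unsubstituted benzyl. The wider change from the ethyl end of the series to the 4-chlorobenzyl, which replaces methyl with 4-chlorophenyl, gives a number 9.5 percentage points higher from compound 1 to compound 3 (within the scatter) and so also stays inside the scatter, which means that none of the three compounds can be separated from another in this assay. No supporting measurement is available to account for these readings.

From the compounds shown here alone, it remains open whether a different group at this place, such as methoxy, an amine or a carboxylic acid, would move the reading beyond the scatter, and whether chloro on another carbon of the same ring would behave as it does here. Because the read-out gives the size of the effect at one concentration, the relative potency of these compounds also remains open.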